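Chalcone triazoles: a benzyl halogen swap on a second core

A few compounds are considered here, and "the series" means these few. Any claim that something is new, unique, unknown or untested is made for them only; others in the source may bear on it.

Of the compounds shown here, three built on one shared core have been tested in a functional assay on MCF7 cells (Homo sapiens) for inhibition, read by MTT assay, with a stated time of 48 h, tested at 10 uM; a lower number here means less inhibition of growth, a higher number more inhibition of growth at the concentration tested. Compound 1 `O=C(/C=C/c1ccc(OCc2cn(Cc3ccc(Br)cc3)nn2)cc1)c1ccc(Br)cc1` gives 23% in this assay. Compound 2 `O=C(/C=C/c1ccc(OCc2cn(Cc3ccccc3F)nn2)cc1)c1ccc(Br)cc1` carries the change (2-fluorophenyl in place of 4-bromophenyl on a saturated chain carbon bound to an aromatic nitrogen); in this assay compound 2 gives 38%, and the step is a number 15 percentage points higher from compound 1 to compound 2 (beyond the scatter). Compound 3 `COc1ccc(C(=O)/C=C/c2ccc(OCc3cn(Cc4ccc(Br)cc4)nn3)cc2)cc1` differs from compound 1 by methoxy in place of bromo on an aromatic carbon; in this assay compound 3 gives 53%, a step of a number 30 percentage points higher from compound 1 to compound 3 (beyond the scatter), and it stands highest of the three, with compound 2 nearest and compound 1 furthest.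

Compound 4 `COc1ccc(C(=O)/C=C/c2ccc(OCc3cn(Cc4ccccc4F)nn3)cc2)cc1` has not yet been measured in this assay. It differs from compound 3 by 2-fluorophenyl in place of 4-bromophenyl on a saturated chain carbon bound to an aromatic nitrogen. This is the same change that leads from compound 1 to compound 2, made on a core that differs from the core of compound 1 in the way already told for compound 3. It occurs twice among these compounds, and only one instance has a measured outcome, so the expectation rests on a single step. Resting on a number 15 percentage points higher from compound 1 to compound 2 (beyond the scatter), the expected step is a number 12 percentage points higher from compound 3 to compound 4 (beyond the scatter). In this assay compound 4 is therefore estimated at 65%. Allowing for the scatter of such measurements, the number for compound 4 is expected to lie between 50% and 80%.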

Compound 4, percent growth inhibition at one concentration: 32%
Compound 4: middle estimate off by 33 percentage points, on the high side; measured number below the stated range.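

In this assay, the swap of 4-bromobenzyl to 2-fluorobenzyl did not carry from the core of compound 1 to the core of compound 3; on the latter it gives a number 21 percentage points lower from compound 3 to compound 4 (beyond the scatter), so the two instances part: the same change on two cores in this assay, a number 15 percentage points higher (beyond the scatter) from compound 1 to compound 2 and a number 21 percentage points lower (beyond the scatter) from compound 3 to compound 4, 36 percentage points apart, beyond the scatter of two such steps. The same holds when the four compounds are read the other way, with methoxy in place of bromo on an aromatic carbon giving a number 6 percentage points lower from compound 2 to compound 4 (within the scatter) on the 2-fluorobenzyl side, against the earlier step on the 4-bromobenzyl side: the same change on two cores in this assay, a number 30 percentage points higher (beyond the scatter) from compound 1 to compound 3 and a number 6 percentage points lower (within the scatter) from compound 2 to compound 4, 36 percentage points apart, beyond the scatter of two such steps. Among these four compounds, then, the outcome of each change depends on what stands at the other place, but with only one pair of steps per change this does not show why, nor does it give a rule for any compound beyond them.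

The swap alters both the halogen and its place on the ring at once, and these compounds do not separate the two, so an unsubstituted benzyl group or a chlorobenzyl group on either core remains an open case. Also open, from the compounds shown here alone, is how a hydroxy group or an amine in place of the methoxy would behave with either benzyl group.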